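From fluoro to methoxy: compound 3 to compound 4

The source may hold more compounds than are shown below. What is called first, only, known or untested is meant among the compounds shown, and "the series" means these compounds.

Of the compounds shown here, three have so far been measured in a physicochemical assay for lipophilicity; on this read-out higher numbers stand for higher lipophilicity and lower numbers for lower lipophilicity. Compound 1 (`O=C1/C(=C/c2ccccc2)CCC/C1=C\c1ccccc1[N+](=O)[O-]`) gives 4.7, compound 2 (`CN(C)c1ccc(/C=C2\CCC/C(=C\c3ccccc3[N+](=O)[O-])C2=O)cc1`) gives 4.8, and compound 3 (`O=C1/C(=C/c2ccc(F)cc2)CCC/C1=C\c1cccc([N+](=O)[O-])c1`) gives 5.07. Compound 3 therefore lies within the usual scatter of compound 2, while it stands clearly above compound 1, beyond that scatter.

Compound 4 (`COc1ccc(/C=C2\CCC/C(=C\c3cccc([N+](=O)[O-])c3)C2=O)cc1`) has not yet been measured. It differs from compound 3 as follows: methoxy in place of fluoro on an aromatic carbon. In short, methoxy stands in place of fluoro on an aromatic carbon, para to a large group, so that 4-fluorophenyl becomes 4-methoxyphenyl.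

Among the compounds with values here, no measured step covers this exchange directly. Within the data shown here, the only single-place step available is a number 0.10 log units higher from compound 1 to compound 2 (within the scatter), which puts dimethylamino in place of hydrogen on an aromatic carbon. Among the measured compounds shown here, it is a different exchange and offers only loose guidance, but it is the sole evidence at hand for a change on an aromatic carbon. For the measured compounds named here, with only the step of a number 0.10 log units higher from compound 1 to compound 2 (within the scatter) to go on, no shift beyond the scatter is expected in this assay. The expected change is small, an estimated a number 0.07 log units lower from compound 3 to compound 4 (within the scatter). For compound 4 the estimated value is 5, with an expected range from 4.7 to 5.3.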

Compound 4, partition coefficient: 4.96
Estimate against measurement, compound 4: 0.04 log units above; the range from low to high includes it.
By their numbers in this assay, from the lowest: compounds 1, 2, 4 and 3 (each within the scatter of the next, the first and the last beyond it).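

In this assay, methoxy in place of fluoro on an aromatic carbon, para to a large group, gives a number 0.11 log units lower from compound 3 to compound 4 (within the scatter), so this read-out does not separate 4-fluorophenyl from 4-methoxyphenyl at this position, even though methoxy brings a hydrogen-bond acceptor that fluoro lacks. The only earlier single-place step, a number 0.10 log units higher from compound 1 to compound 2 (within the scatter), put dimethylamino in place of hydrogen, whereas this is the first step shown that exchanges one substituent for another on an aromatic carbon, and it too stays within the scatter. The data give no measured property that would account for how close these values lie, and the result stands as an observation only.

Still open, as far as these compounds go, is whether a carboxylic acid, an amine or a longer alkoxy chain on this same aromatic carbon would also stay within the scatter of compound 3, or would move the read-out beyond it. Also open, from the compounds shown here alone, is whether the exchange of fluoro for methoxy would give a similar step on the core of compound 1, since both compounds of this step share the core of compound 3.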